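A Methyl Added to a Weak Carboxylic Acid Inhibitor

The compounds below may be only part of what the source reports. "The series", "measured", "known", "first", "only" and "open" are said of these compounds alone.

Compound 1 `O=C(O)C1CCN(c2ccccc2)C1` and compound 2 `Cc1cc(C(=O)O)c[nH]1` both carry a carboxylic acid, but the difference between their two cores is not broken down here. In an assay on cells for inhibition of Palmitoleoyl-protein carboxylesterase NOTUM variant C330S (Homo sapiens), read by fluorescence, with a stated time of 40 min (a higher number here means a weaker inhibitor, a lower number a stronger inhibitor), compound 1 gives 48000 nM, and compound 2 gives 100000 nM; compound 1 has the lower of the two numbers, and its gap to compound 2 lies beyond the usual scatter.

Compound 3 `Cc1cc(C(=O)O)c(C)[nH]1` differs from compound 2 by methyl in place of hydrogen on an aromatic carbon. Compound 3 is recorded only as a limit of the assay, > 100000 nM, not as a number. The step of a number no lower from compound 2 to compound 3 (the limit leaves the size open) thus has no readable size because the limit of > 100000 nM in this assay, at which 1 of the 3 values shown sits, caps what can be seen.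

Compound 4 `Cc1cccc(N2CCC(C(=O)O)C2)c1` differs from compound 1 by methyl in place of hydrogen on an aromatic carbon. This is the same kind of change as from compound 2 to compound 3, yet the place differs: there the methyl sits on a five-membered aromatic ring with 1 nitrogen, next to the ring nitrogen and next to the ring atom that bears a carboxy group; here it sits on a six-membered aromatic ring of carbon only, meta to a group of 8 heavy atoms. With no readable measured step to lean on, the expectation for compound 4 rests on compound 1 at 48000 nM and an expected step of no change at the digits printed from compound 1 to compound 4 (within the scatter). Compound 4 is therefore estimated at 48000 nM, expected to fall between 15000 nM and 100000 nM.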

Compound 4, half-maximal inhibitory concentration: 49000 nM
The estimate for compound 4 lay 1.0-fold (0.01 log units) below the measured number; measured number inside the range.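

In this assay, placing the methyl on the core of compound 1 gives a 1.0-fold higher number from compound 1 to compound 4 (0.01 log units; within the scatter), so on this core the added methyl leaves no mark beyond the usual scatter. Compound 3 is recorded only as a limit of the assay, > 100000 nM, so the step to it from compound 2 cannot be read. The result therefore shows what this methyl does at one place on one core, but it does not show whether the same change carries over to the other core, as the side-by-side comparison makes plain: the same change on two cores in this assay, a number no lower (the limit leaves the size open) from compound 2 to compound 3 and a 1.0-fold higher number (0.01 log units; within the scatter) from compound 1 to compound 4; the limit leaves it open whether they differ

The compounds shown leave open whether a different group in the same place on the six-membered aromatic ring of compound 1, such as a chlorine atom or a methoxy group, would move the number beyond the scatter. They also leave open how either core would read with an amide in place of the carboxylic acid.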